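The source may report more compounds than this note shows. Statements on the series, on what has been measured and on what is new or still open speak of the compounds shown alone.

Three compounds on one shared core differ only in the group on a single aromatic carbon: fluoro in compound 1 (`CC(=O)N[C@@H]1CCC[C@H](C(=O)Nc2cc(-c3cnn4c3CC(C)(C)C4)c(F)cn2)C1`), chloro in compound 2 (`CC(=O)N[C@@H]1CCC[C@H](C(=O)Nc2cc(-c3cnn4c3CC(C)(C)C4)c(Cl)cn2)C1`) and cyano in compound 3 (`CC(=O)N[C@@H]1CCC[C@H](C(=O)Nc2cc(-c3cnn4c3CC(C)(C)C4)c(C#N)cn2)C1`). In a physicochemical assay for lipophilicity, using the shake flask method, measured as octanol-water partition, at pH 7.4 (a lower number here means a more polar compound, a higher number a more lipophilic compound), compound 1 gives 3.3 and compound 2 gives 3.8 while compound 3 gives 3.2 as its reading. The fluoro and cyano compounds cannot be told apart, the measured step being a number 0.10 log units lower from compound 1 to compound 3 (within the scatter) and no more. The chloro compound stands apart, with a number 0.50 log units higher from compound 1 to compound 2 (beyond the scatter) on one side and a number 0.60 log units lower from compound 2 to compound 3 (beyond the scatter) on the other. So compound 3 shares the low end of this small set with compound 1, and compound 2 stands above both.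

Compound 4 (`CC(=O)N[C@@H]1CCC[C@H](C(=O)Nc2cc(-c3cnn4c3CC(C)(C)C4)c(C)cn2)C1`) has not been measured yet. It differs from compound 3 by one change, methyl in place of cyano on an aromatic carbon. Within the data shown here, no measured step involves methyl, so the data give no direct answer. Among the measured compounds shown here, the two modest steps involving chloro show only how far this position has moved the number so far. The working assumption is that methyl lands between the cyano and chloro readings, a little closer to compound 2 with its 3.8 reading. In this assay a modest rise is therefore expected, estimated as a number 0.40 log units higher from compound 3 to compound 4 (beyond the scatter) overall. Compound 4 is estimated at 3.6 with an expected range of 3.2 to 4 around that figure.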

Compound 4, distribution coefficient: 3.1
Beside the measured number, compound 4's estimate is 0.50 log units above it; measured number below the stated range.
By their numbers in this assay, from the lowest: compounds 4, 3 and 1 (each within the scatter of the next); then compound 2.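

In this assay methyl falls in with fluoro and cyano on this aromatic carbon, with a number 0.10 log units lower from compound 3 to compound 4 (within the scatter) and a number 0.20 log units lower from compound 1 to compound 4 (within the scatter) as well, so these three groups cannot be told apart here. Chloro is now set off from all three, with a number 0.70 log units lower from compound 2 to compound 4 (beyond the scatter) completing the picture, and it alone stands apart among the four groups tried at this position. The change from cyano to methyl takes away a triple bond and the hydrogen-bond acceptor counted on cyano, and one heavy atom goes with them, yet the step stays within the scatter, and nothing measured here accounts for that or for chloro standing apart.

The compounds shown leave open whether an amine, a carboxylic acid or a longer chain such as propyl on this same carbon would stay with the low group, reach the chloro compound or go further in either direction. They also leave open whether bromo would read like chloro, and whether these four groups would keep the same pattern on a different core.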